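Removing the tert-butoxycarbonyl group from compound 2

The source may report more compounds than this note shows. Statements on the series, on what has been measured and on what is new or still open speak of the compounds shown alone.

Compound 1 `O=C(c1cccc(Cl)c1)N1CCC(NS(=O)(=O)c2cc(S(=O)(=O)c3ccccc3)ccc2C(F)(F)F)CC1` gives 300 nM in an assay on isolated protein for displacement of a labelled ligand from secreted frizzled-related protein 1 (Homo sapiens), read by fluorescence polarization, with a stated time of 30 min; on this read-out higher numbers stand for weaker inhibition and lower numbers for stronger inhibition.
Compound 2 `CC(C)(C)OC(=O)N1CC[C@@H](C(=O)N2CCC(NS(=O)(=O)c3cc(S(=O)(=O)c4ccccc4)ccc3C(F)(F)F)CC2)C1` gives 50 nM in this assay.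

Compound 2 stands at the lower of the two numbers, with compound 1 higher by a 6.0-fold lower number from compound 1 to compound 2 (0.78 log units; beyond the scatter). Compound 3 `O=C([C@H]1CCNC1)N1CCC(NS(=O)(=O)c2cc(S(=O)(=O)c3ccccc3)ccc2C(F)(F)F)CC1` differs from compound 2 by pyrrolidin-3-yl in place of 1-(tert-butoxycarbonyl)pyrrolidin-3-yl on a carbonyl carbon. Among the compounds with values here, no measured step covers this change: the only step, a 6.0-fold lower number from compound 1 to compound 2 (0.78 log units; beyond the scatter), swapped a different group on the same carbonyl carbon, so it gives no direct guide. Compound 3 is therefore expected to give 100 nM, within 25 nM to 400 nM. This estimate means an expected step of a 2.0-fold higher number from compound 2 to compound 3 (0.30 log units; within the scatter), close to the scatter.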

Compound 3, half-maximal inhibitory concentration: 40 nM
Estimate against measurement, compound 3: 2.5-fold (0.40 log units) above; measured number inside the range.
By their numbers in this assay, from the lowest: compounds 3 and 2 (each within the scatter of the next); then compound 1.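

Exchanging the tert-butoxycarbonyl-bearing group on this carbonyl carbon for plain pyrrolidin-3-yl gives a 1.3-fold lower number from compound 2 to compound 3 (0.10 log units; within the scatter), so the tert-butoxycarbonyl group can go with no real shift in the number. The bare pyrrolidine ring alone still keeps the advantage over 3-chlorophenyl, with a 7.5-fold lower number from compound 1 to compound 3 (0.88 log units; beyond the scatter). No measurement here explains why the number holds. As far as these compounds go, what a small methyl or acetyl group on the pyrrolidine nitrogen would give stays open. So does the effect of the opposite stereocentre in the ring.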